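This account rests on a few compounds, and the source may have more. Where it says the series, first, only, none or still open, it means among the compounds named here.

Three close relatives share one core. Compound 1 `Cn1ccc2c(Oc3ccc(NC(=O)c4cc5cccnc5n(-c5ccccc5)c4=O)cc3)ccnc21` carries a plain phenyl group on that core, and in a functional assay on NCI-H460 cells (Homo sapiens) for antiproliferative activity, read by MTT assay, with a stated time of 72 h (a higher number here means a weaker inhibitor, a lower number a stronger inhibitor), compound 1 gives 560 nM. Compound 2 `Cn1ccc2c(Oc3ccc(NC(=O)c4cc5cccnc5n(-c5ccc(Cl)cc5)c4=O)cc3)ccnc21` carries a chloro on the same phenyl, but in this assay compound 2 gives "not determined" (no result reported), so where it stands among these compounds cannot be said. Compound 3 `COc1ccc(-n2c(=O)c(C(=O)Nc3ccc(Oc4ccnc5c4ccn5C)cc3)cc3cccnc32)cc1` differs from compound 2 in one place: methoxy in place of chloro on an aromatic carbon. Among the compounds with values here, compound 2 lacks a number, so no measured step leads to compound 3, and the size and direction of any shift in this assay from that exchange cannot be read from the data; the only anchor is compound 1 with 560 nM, and a change of this kind is not expected to move the result beyond the usual scatter around it. Compound 3 in this assay is therefore expected to give about 500 nM, within a range from 150 nM to 2000 nM.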

Compound 3, half-maximal inhibitory concentration: 1920 nM
Compound 3: the middle estimate sits 3.8-fold (0.58 log units) below what was measured; the range from low to high includes it.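

In this assay, adding methoxy to the plain phenyl group gives a 3.4-fold higher number from compound 1 to compound 3 (0.54 log units; beyond the scatter), so this position responds to substitution, and this change makes the compound a modestly weaker inhibitor. Within the data shown here, it is the only measured step at this position, and it shows that the 4-methoxyphenyl group lowers the activity without abolishing it. Nothing in the available data explains this shift.

Going by these compounds, compound 2 has no number, so the exchange of chloro for methoxy cannot be read, and it remains unknown whether the 4-chlorophenyl group would stand closer to compound 1 or to compound 3. The compounds shown also leave open how an amine, a carboxylic acid or a longer chain such as ethoxy would behave at this position, and so whether any group here could improve on the plain phenyl group.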